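The compounds below may be only part of what the source reports. "The series", "measured", "known", "first", "only" and "open" are said of these compounds alone.

In a functional assay, with a stated time of 6 min (on this read-out higher numbers stand for weaker inhibition and lower numbers for stronger inhibition), the measured compounds read:

- compound 1 `Fc1cccc(F)c1NCn1nc(-c2ccc3c(c2)OCCO3)oc1=S` gives 3320 nM
- compound 2 `S=c1oc(-c2ccc3c(c2)OCCO3)nn1CNc1cccc(Cl)c1` gives 6220 nM
- compound 3 `O=[N+]([O-])c1cccc(NCn2nc(-c3ccc4c(c3)OCCO4)oc2=S)c1` gives 8870 nM

Compound 3 stands at the upper end of these three numbers: a 1.4-fold higher number from compound 2 to compound 3 (0.15 log units; within the scatter) stays within the scatter, whereas a 2.7-fold higher number from compound 1 to compound 3 (0.43 log units; beyond the scatter) goes beyond it. The step now in view is 4-methylphenyl in place of 3-nitrophenyl on an amine nitrogen, and it gives compound 4 `Cc1ccc(NCn2nc(-c3ccc4c(c3)OCCO4)oc2=S)cc1` with the shared core unchanged. Among the compounds with values here, no measured compound carries the 4-methylphenyl, so the evidence is only indirect. Changes on the amine nitrogen have so far moved the number little: a 1.9-fold higher number from compound 1 to compound 2 (0.27 log units; within the scatter) lies within the scatter, and a 2.7-fold higher number from compound 1 to compound 3 (0.43 log units; beyond the scatter) is the largest and still modest. A step beyond the scatter is therefore not expected in this assay for this change, and its direction cannot be firmly told. The estimated change is a 1.5-fold lower number from compound 3 to compound 4 (0.17 log units; within the scatter) and stays within the scatter. Compound 4 is expected at 6000 nM with 2500 nM to 14000 nM as the estimated range.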

Compound 4, half-maximal inhibitory concentration: 5700 nM
Compound 4: the middle estimate sits 1.1-fold (0.02 log units) above what was measured; the range from low to high includes it.
By their numbers in this assay, from the lowest: compounds 1, 4, 2 and 3 (each within the scatter of the next, the first and the last beyond it).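

In this assay, the all-carbon 4-methylphenyl on the amine nitrogen reads within the scatter of each of the three earlier aryl groups: the 3-nitrophenyl (a 1.6-fold lower number from compound 3 to compound 4 (0.19 log units; within the scatter)), the 3-chlorophenyl (a 1.1-fold lower number from compound 2 to compound 4 (0.04 log units; within the scatter)) and the 2,6-difluorophenyl (a 1.7-fold higher number from compound 1 to compound 4 (0.23 log units; within the scatter)). So this position accepts an aryl group with no hydrogen-bond acceptors and no halogen without a step beyond the scatter, and compound 4 lies within the scatter of both compound 1 and compound 3, the one pair printed as beyond it. Nothing available accounts for how closely these aryl groups read.

Compound 4 changes both the group and its place on the ring, so the two effects remain unseparated, and 3-methylphenyl would be the direct comparison with compound 2 and compound 3. As far as these compounds go, it also remains open whether anything other than a substituted phenyl, such as a cyclohexyl ring or a longer alkyl chain, would hold the number on this amine nitrogen.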